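From pyridin-2-yl to 2-chloro-6-fluorophenyl on compound 2

A few compounds are considered here, and "the series" means these few. Any claim that something is new, unique, unknown or untested is made for them only; others in the source may bear on it.

Compound 1 `COc1ccc(/C=N/NC(=S)N/N=C2\C(=O)Nc3ccc(C)cc32)cc1O` gives 3190 nM in a functional assay on COS-7 cells (Chlorocebus aethiops) for inhibition, read by MTT assay; a higher number here means a weaker inhibitor, a lower number a stronger inhibitor.
Compound 2 `Cc1ccc2c(c1)/C(=N/NC(=S)N/N=C/c1ccccn1)C(=O)N2` gives 2120 nM in this assay.
Compound 3 `O=C1Nc2ccc(Br)cc2/C1=N/NC(=S)N/N=C/c1ccc2ccccc2c1` gives > 50000 nM in this assay, which is a limit of the assay rather than a number.

Among the two numbers shown, compound 2 has the lower one; its nearest neighbour is compound 1, and the step of a 1.5-fold lower number from compound 1 to compound 2 (0.18 log units; within the scatter) lies within the usual scatter. The remaining value is the limit of > 50000 nM in this assay, at which 1 of the 3 values shown sits.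

Compound 4 `Cc1ccc2c(c1)/C(=N/NC(=S)N/N=C/c1c(F)cccc1Cl)C(=O)N2` has not yet been measured. It differs from compound 2 in one place: 2-chloro-6-fluorophenyl in place of pyridin-2-yl on a carbon with a double bond to nitrogen. Within the data shown here, the only measured step that touches this carbon is the one from compound 1 to compound 2, where one six-membered aromatic ring replaced another and the number barely moved. Compound 4 again exchanges one six-membered aromatic ring for another at the same carbon, so no step beyond the scatter is expected in this assay. The step this estimate implies, a 1.2-fold higher number from compound 2 to compound 4 (0.07 log units; within the scatter), is expected to stay within the scatter. Compound 4 is therefore estimated at 2500 nM, in a range from 700 nM to 9000 nM.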

Compound 4, half-maximal inhibitory concentration: 2190 nM
Compound 4: middle estimate off by 1.1-fold (0.06 log units), on the high side; low and high end bracket the measured number.
By their numbers in this assay, from the lowest: compounds 2, 4 and 1 (each within the scatter of the next). At a limit, above all of these: compound 3.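

In this assay, the exchange of pyridin-2-yl for 2-chloro-6-fluorophenyl gives a 1.0-fold higher number from compound 2 to compound 4 (0.01 log units; within the scatter), so at this carbon the ring nitrogen of pyridin-2-yl can be lost and chlorine and fluorine brought in without the number leaving the scatter. The comparison with the other carbon-only ring gives a 1.5-fold lower number from compound 1 to compound 4 (0.16 log units; within the scatter), which makes compounds 1, 2 and 4 a set of three different aromatic rings at this carbon, all within the scatter of each other. Nothing given here explains why this exchange leaves the number where it is.

Compound 3 gives > 50000 nM, a limit of the assay rather than a number, and it differs from these compounds in more than one place, so it cannot be tied to this carbon alone. Still open, from the compounds shown here alone, is whether a ring carrying an amine or a carboxylic acid, or a longer chain in place of the ring, would stay within the scatter at this carbon.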